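Chain-end phenoxy removal in a hydroxamate series

This account rests on a few compounds, and the source may have more. Where it says the series, first, only, none or still open, it means among the compounds named here.

Compound 1 `Cc1ccc(-c2cnc(N(CCCCOc3ccccc3)Cc3ccc(C(=O)NO)cc3)s2)cc1` and compound 3 `Cc1ccc(-c2cnc(N(CCCOc3ccccc3)Cc3ccc(C(=O)NO)cc3)s2)cc1` have cores that differ by phenoxy in place of phenoxymethyl on a saturated chain carbon, three bonds along the chain from a nitrogen on an aromatic ring. In a functional assay on HepG2 cells (Homo sapiens) for antiproliferative activity, read by MTT assay, with a stated time of 48 h (a higher number here means a weaker inhibitor of growth, a lower number a stronger inhibitor of growth), compound 1 gives 16600 nM and compound 3 gives 23400 nM; the step is a 1.4-fold higher number from compound 1 to compound 3 (0.15 log units; within the scatter). Compound 2 `CCCCN(Cc1ccc(C(=O)NO)cc1)c1ncc(-c2ccc(C)cc2)s1` differs from compound 1 by hydrogen in place of phenoxy on a saturated chain carbon, four bonds along the chain from a nitrogen on an aromatic ring, and in this assay compound 2 gives 4300 nM, so the change made a 3.9-fold lower number from compound 1 to compound 2 (0.59 log units; beyond the scatter). Between them, a 5.4-fold higher number from compound 2 to compound 3 (0.74 log units; beyond the scatter). Compound 4 `CCCN(Cc1ccc(C(=O)NO)cc1)c1ncc(-c2ccc(C)cc2)s1` differs from compound 3 by hydrogen in place of phenoxy on a saturated chain carbon, three bonds along the chain from a nitrogen on an aromatic ring. This is the same kind of change as from compound 1 to compound 2, not the same one: there the place was four bonds along the chain from a nitrogen on an aromatic ring, here it is three. The step from compound 3 to compound 4 is expected to be a 4.3-fold lower number from compound 3 to compound 4 (0.63 log units; beyond the scatter) because a 3.9-fold lower number from compound 1 to compound 2 (0.59 log units; beyond the scatter). That would put compound 4 close to compound 2, which gives 4300 nM. Compound 4 is estimated at 5500 nM, expected to fall between 2500 nM and 12000 nM.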

Compound 4, concentration for 50% growth inhibition: 2550 nM
Compound 4: the middle estimate sits 2.2-fold (0.33 log units) above what was measured; the measured number falls inside the stated range.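

In this assay, hydrogen in place of phenoxy gives a 9.2-fold lower number from compound 3 to compound 4 (0.96 log units; beyond the scatter) and so carries over in direction from one chain length to the other, with no gap between the two steps beyond the scatter: the same change on two cores in this assay, a 3.9-fold lower number (0.59 log units; beyond the scatter) from compound 1 to compound 2 and a 9.2-fold lower number (0.96 log units; beyond the scatter) from compound 3 to compound 4, 2.4-fold (0.38 log units) apart, within the scatter of two such steps.
Without the phenoxy, the chain change gives a 1.7-fold lower number from compound 2 to compound 4 (0.23 log units; within the scatter) while hydrogen in place of phenoxymethyl gives a 6.5-fold lower number from compound 1 to compound 4 (0.81 log units; beyond the scatter) and so the loss of the phenoxy end, not the chain length, accounts for the larger steps among these compounds.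
Only two matched pairs support this, and they differ only in chain length, so transfer to a core changed elsewhere is not shown.

Still open, on these data alone, is whether a chain end bearing an amine or a carboxylic acid behaves like the phenoxy end or like hydrogen. A longer chain without the phenoxy also remains to be placed.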